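Swapping Isopropyl for Methoxyethyl on a Shared Core

The source may report more compounds than this note shows. Statements on the series, on what has been measured and on what is new or still open speak of the compounds shown alone.

Of the compounds shown here, three built on a shared core have been tested in an assay on HEK-293T cells for inhibition of Bile acid receptor (Homo sapiens), read by a beta-lactamase reporter, with a stated time of 16 h; a higher number here means a weaker inhibitor, a lower number a stronger inhibitor. Compound 1 `Cc1ccc(-c2nn(Cc3ccc4ccccc4c3)cc2C(=O)Nc2ccc(C)c(S(=O)(=O)N3CCOCC3)c2)cc1` gives 844 nM in this assay. Compound 3 `Cc1ccc(NC(=O)c2cn(C(C)C)nc2-c2ccc(C(F)(F)F)cc2)cc1S(=O)(=O)N1CCOCC1` gives 1950 nM. Compound 2 `COc1cccc(Cn2cc(C(=O)Nc3ccc(C)c(S(=O)(=O)N4CCOCC4)c3)c(C(C)C)n2)c1` gives 3110 nM, the highest of the three numbers; its gap to compound 3 lies within the usual scatter of repeated measurements, while its gap to compound 1 lies beyond it, so compound 1 is the stronger inhibitor of the two.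

Compound 4 `COCCc1nn(Cc2cccc(OC)c2)cc1C(=O)Nc1ccc(C)c(S(=O)(=O)N2CCOCC2)c1` has not yet been measured. It differs from compound 2 in one place: 2-methoxyethyl in place of isopropyl on an aromatic carbon. Among the measured compounds shown here, no pair among the measured compounds differs only at this position, so there is no measured step to lean on. The rest of the molecule, including the 3-methoxybenzyl group and the amide-linked part of the core, stays the same, and one short chain is exchanged for another.

With nothing pointing clearly one way, only a small step is expected, a 1.1-fold higher number from compound 2 to compound 4 (0.05 log units; within the scatter), and none beyond the scatter. Compound 4 is therefore expected to give about 3500 nM in this assay, with a range from 1200 nM to 10000 nM.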

Compound 4, half-maximal inhibitory concentration: 11100 nM
Compound 4: the middle estimate sits 3.2-fold (0.50 log units) below what was measured; the whole stated range lies below it.
By their numbers in this assay, from the lowest: compound 1; then compounds 3 and 2 (each within the scatter of the next); then compound 4.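

In this assay, among the compounds shown here, this position on the shared core proves sensitive to exchanging one short chain for another: 2-methoxyethyl in place of isopropyl gives a 3.6-fold higher number from compound 2 to compound 4 (0.55 log units; beyond the scatter), the only measured step here at this place, since the earlier compounds differ from one another in more than one place. The change looks small on paper, with 2-methoxyethyl having 4 heavy atoms, one of them oxygen, and 1 hydrogen-bond acceptor, where isopropyl has 3 heavy atoms, all carbon, and 0 hydrogen-bond acceptors, yet it is enough to make compound 4 a weaker inhibitor than compound 2. No measurement at hand explains why the number rises at this position.

The compounds shown leave open whether a plain carbon chain such as n-propyl or n-butyl would match compound 2 or compound 4, which would help separate the length of the chain from the presence of its oxygen. They also leave open how an amine or a carboxylic acid would fare at this place, and whether the same exchange would give a step of similar size with another group in place of the 3-methoxybenzyl group.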